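This account rests on a few compounds, and the source may have more. Where it says the series, first, only, none or still open, it means among the compounds named here.

Measured so far:
compound 1, `CC(C)(C)c1ccc(CCCN2CC=C(CCC(=O)NO)C2=O)cc1`: 2.7
compound 2, `O=C(CCC1=CCN(Cc2ccc(F)cc2)C1=O)NO`: 0.571

In a physicochemical assay for lipophilicity (a lower number here means a more polar compound, a higher number a more lipophilic compound), compound 2 gives 0.571, the lowest of the two numbers; the nearest is compound 1 with 2.7, a gap that lies beyond the scatter. Compound 3 is `N#Cc1ccc(CN2CC=C(CCC(=O)NO)C2=O)cc1`; it differs from compound 2 in that (cyano in place of fluoro on an aromatic carbon). For the measured compounds named here, no step between measured compounds bears on this change; the expectation rests on the change alone. Compound 3 is expected to come out somewhat more polar, with the step of a number 0.57 log units lower from compound 2 to compound 3 (beyond the scatter) estimated to exceed the scatter in the downward direction. For compound 3 the estimate in this assay is 0, between -0.5 and 0.5.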

Compound 3, distribution coefficient: 0.197
Compound 3: middle estimate off by 0.20 log units, on the low side; the range from low to high includes it.
By their numbers in this assay, from the lowest: compound 3; then compound 2; then compound 1.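

With the first step read at this place, on an aromatic carbon para to a large group, this assay shows that cyano in place of fluoro gives a number 0.37 log units lower from compound 2 to compound 3 (beyond the scatter) and so moves the number modestly. The position therefore registers this exchange, and the direction is downward. No measurement at hand accounts for the step. On these data alone, whether an amine or a carboxylic acid on the same aromatic carbon would move the number further remains open. So does whether the step keeps its size with a longer linking chain.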